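A Shift on the Amide Nitrogen of Compound 2

The source may report more compounds than this note shows. Statements on the series, on what has been measured and on what is new or still open speak of the compounds shown alone.

Compound 2 `O=C(Nc1cc(Cl)ccc1O)c1cc2cc(Cl)cc(Br)c2oc1=O` gives the higher of the two numbers measured in an assay on isolated protein for inhibition of coagulation factor XII (Homo sapiens), read by HPLC, with stated times of 10 min and 30 min, tested at 50 uM (a lower number here means less inhibition, a higher number more inhibition at the concentration tested (going by the name of the read-out)), showing 99%, whereas compound 1 `CCN(CC)Cc1ccc2oc(=O)c(C(=O)Nc3ccccc3)cc2c1` gives 14% in this assay, a gap beyond the scatter. Compound 3 `O=C(Nc1cccc(O)c1)c1cc2cc(Cl)cc(Br)c2oc1=O` differs from compound 2 by 3-hydroxyphenyl in place of 5-chloro-2-hydroxyphenyl on an amide-type nitrogen. Since compound 2 sits near the top of the scale, the expected step of a number 24 percentage points lower from compound 2 to compound 3 (beyond the scatter) in this assay is downward and moderate. Compound 3 is therefore estimated at 75% in this assay, within a range of 40% to 97%.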

Compound 3, a percentage reported as inhibition, at one concentration (the size of the read-out at that concentration, not a potency): 90%
Compound 3: middle estimate off by 15 percentage points, on the low side, within the range that was stated.
By their numbers in this assay, from the lowest: compound 1; then compounds 3 and 2 (each within the scatter of the next).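

Among these compounds, compound 2 and compound 3 are the first pair here that differ in one place, and the exchange of 5-chloro-2-hydroxyphenyl for 3-hydroxyphenyl on this amide-type nitrogen gives a number 9 percentage points lower from compound 2 to compound 3 (within the scatter) in this assay. At this concentration, the two groups cannot be told apart. Nothing given here bears on why this is so.

From the compounds shown here alone, it remains open how an unsubstituted phenyl, a carboxylic acid or an amine would read on this nitrogen with the same core. Going by these compounds, whether the two groups would also match at lower concentrations also stays open.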